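The source may report more compounds than this note shows. Statements on the series, on what has been measured and on what is new or still open speak of the compounds shown alone.

Of the compounds shown here, three built on one shared core have been tested in a functional assay on UACC-257 cells (Homo sapiens) for cytotoxicity, read by sulforhodamine B assay, with a stated time of 48 h; a lower number here means a stronger inhibitor of growth, a higher number a weaker inhibitor of growth. Compound 1 `ClCc1ccccc1Cn1cnc2c(Cl)nc(Cl)nc21` gives 1820 nM. Compound 2 `ClCc1ccccc1Cn1cnc2c(Cl)ncnc21` gives 10700 nM in this assay, and compound 3 `ClCc1ccc(Cn2cnc3c(Cl)nc(Cl)nc32)cc1` gives 16200 nM. Among the measured compounds shown here, compound 2 thus lies within the scatter of compound 3, while the single measured step, a 5.9-fold higher number from compound 1 to compound 2 (0.77 log units; beyond the scatter), separates it from compound 1 beyond the scatter.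

Compound 4 `Nc1nc(Cl)c2ncn(Cc3ccccc3CCl)c2n1` has not yet been measured in this assay. It differs from compound 2 by amino in place of hydrogen on an aromatic carbon, the amino group entering between two ring nitrogen atoms, meta to a chloro group, meta to a fused ring and para to a fused ring. For the measured compounds named here, no measured step exchanges hydrogen for amino. Going by the values given here, the only step at that carbon, a 5.9-fold higher number from compound 1 to compound 2 (0.77 log units; beyond the scatter), was beyond the scatter, so a step beyond the scatter is possible here too, but its direction is not fixed by the data. Compound 4 is therefore expected to give a number near that of compound 2 or somewhat lower, a 1.8-fold lower number from compound 2 to compound 4 (0.25 log units; within the scatter). The estimate for compound 4 in this assay is 6000 nM, with a range from 1500 nM to 25000 nM.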

Compound 4, concentration for 50% growth inhibition: 13200 nM
Estimate against measurement, compound 4: 2.2-fold (0.34 log units) below; the range from low to high includes it.
By their numbers in this assay, from the lowest: compound 1; then compounds 2, 4 and 3 (each within the scatter of the next).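

At the aromatic carbon between two ring nitrogen atoms, this assay does not separate amino from hydrogen (a 1.2-fold higher number from compound 2 to compound 4 (0.09 log units; within the scatter)), so adding this small group with a hydrogen-bond donor there gives no step beyond the scatter. Set against chloro at the same carbon, amino gives a step beyond the scatter (a 7.3-fold higher number from compound 1 to compound 4 (0.86 log units; beyond the scatter)), as hydrogen does (a 5.9-fold higher number from compound 1 to compound 2 (0.77 log units; beyond the scatter)), so among these three groups only chloro stands apart, with the lower number. Nothing shown here gives a reason for this difference.

Going by these compounds, it remains open whether a bromo group, a methoxy group or a methylamino group at this carbon would stay with chloro or fall with hydrogen and amino. The compounds shown also leave open whether amino would give the same result on the core of compound 3.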